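A few compounds are considered here, and "the series" means these few. Any claim that something is new, unique, unknown or untested is made for them only; others in the source may bear on it.

The shared core of these compounds carries a chain on one aromatic nitrogen and a thioether linker to a dichlorophenyl amide, and the three measured members differ in those two places. Compound 1 `Cn1c(Cc2nn(C)c(=O)c3ccccc23)nnc1SCC(=O)Nc1ccc(Cl)cc1Cl` gives 7700 nM in an assay on NK92 cells for inhibition of interleukin-2 (Homo sapiens), read by AlphaScreen, with stated times of 30 min and 1 h; a higher number here means a weaker inhibitor, a lower number a stronger inhibitor. Compound 2 `CCOC(CCn1c(Cc2nn(C)c(=O)c3ccccc23)nnc1SCCCCCCCC(=O)Nc1ccc(Cl)cc1Cl)OCC` reports only a limit in this assay, > 30000 nM. Compound 3 `Cn1c(Cc2nn(CCC=O)c(=O)c3ccccc23)nnc1SCC(=O)Nc1ccc(Cl)cc1Cl` likewise reports a limit in this assay, > 30000 nM. Compound 3 therefore stands on a limit and not on a number, which matches (the limit of > 30000 nM in this assay, at which 2 of the 3 values shown sit). Among the compounds with values here, the single step that leads to it, an at least 3.8-fold higher number from compound 1 to compound 3 (0.59 log units; beyond the scatter), shows that adding the formylmethyl chain pushed the number past the limit.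

Compound 4 `Cn1c(Cc2nn(CCC(=O)O)c(=O)c3ccccc23)nnc1SCC(=O)Nc1ccc(Cl)cc1Cl` differs from compound 3 by hydroxy in place of hydrogen on a carbonyl carbon whose other neighbour is a saturated chain carbon, turning formyl into carboxy. Within the data shown here, no measured step touches this change; only an at least 3.8-fold higher number from compound 1 to compound 3 (0.59 log units; beyond the scatter) concerns the same chain, and it ended at a limit. For compound 4 the expected step in this assay is thus none beyond the scatter, a step that the limit leaves unreadable from compound 3 to compound 4. Compound 4 is estimated at 35000 nM, between 10000 nM and 100000 nM, most likely reported again as a limit.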

Compound 4, half-maximal inhibitory concentration: > 30000 nM
Compound 4 ended at the assay's limit (the forecaster's own chance of this, stated with the estimate: 70%); the middle value lies beyond the limit too.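

In this assay, the chain that ends in carboxy gives an at least 3.8-fold higher number from compound 1 to compound 4 (0.59 log units; beyond the scatter), a step of the same printed size as an at least 3.8-fold higher number from compound 1 to compound 3 (0.59 log units; beyond the scatter). Two different chain ends, formyl and carboxy, have now both taken the number past the limit, so the loss at this position is not tied to the formyl group alone. Compound 3 and compound 4 both stand on limits, so the step between them cannot be read and the effect of hydroxy in place of hydrogen on the carbonyl carbon stays unknown: the limit of > 30000 nM in this assay, at which 3 of the 4 values shown sit.

The compounds shown leave open how far past the limit compound 3 and compound 4 lie, and whether any chain at this position keeps a measurable number. A plain propyl chain, or a chain ending in an amine or a primary amide, could tell whether the loss follows the chain itself or its end group, while the separate contributions of the two changes in compound 2 also remain unresolved.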